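Series notes: 3,4-difluorophenyl for 3,4-dichlorophenyl on the carbonyl

The compounds below may be only part of what the source reports. "The series", "measured", "known", "first", "only" and "open" are said of these compounds alone.

Measured so far:
compound 1 `CN(C(=O)NC(=O)c1ccc([N+](=O)[O-])cc1)c1nc(C(F)(F)F)c(C(=O)N/N=C/c2ccc([N+](=O)[O-])cc2)s1` — 9.24 ug/mL
compound 2 `CN(C(=O)NC(=O)c1ccc(F)c(F)c1)c1nc(C(F)(F)F)c(C(=O)N/N=C/c2ccccc2C(F)(F)F)s1` — 8.21 ug/mL
compound 3 `CN(C(=O)NC(=O)c1ccc(Cl)c(Cl)c1)c1nc(C(F)(F)F)c(C(=O)N/N=C/c2ccc([N+](=O)[O-])cc2)s1` — 6.74 ug/mL

In a functional assay on MCF7 cells (Homo sapiens) for inhibition, read by MTT assay, with a stated time of 72 h (a lower number here means a stronger inhibitor, a higher number a weaker inhibitor), compound 3 gives the lowest of the three numbers, yet both neighbours sit within the scatter: compound 2 gives 8.21 ug/mL and compound 1 gives 9.24 ug/mL, so no order among the three can be claimed.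

Compound 4 `CN(C(=O)NC(=O)c1ccc(F)c(F)c1)c1nc(C(F)(F)F)c(C(=O)N/N=C/c2ccc([N+](=O)[O-])cc2)s1` differs from compound 3 in one place: 3,4-difluorophenyl in place of 3,4-dichlorophenyl on a carbonyl carbon. Within the data shown here, the only step so far at this carbonyl carbon, a 1.4-fold lower number from compound 1 to compound 3 (0.14 log units; within the scatter), stayed within the scatter. Compound 2 already carries the 3,4-difluorophenyl, but with a different aryl on the hydrazone side, so its number and that of compound 4 cannot be read as a step. The expectation is therefore no change beyond the scatter, a 1.1-fold higher number from compound 3 to compound 4 (0.05 log units; within the scatter). Compound 4 is estimated at 7.5 ug/mL, with a range of 4 ug/mL to 14 ug/mL in this assay.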

Compound 4, half-maximal inhibitory concentration: 4.81 ug/mL
Beside the measured number, compound 4's estimate is 1.6-fold (0.19 log units) above it; the measured number falls inside the stated range.
By their numbers in this assay, from the lowest: compounds 4, 3, 2 and 1 (each within the scatter of the next).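

With a 1.4-fold lower number from compound 3 to compound 4 (0.15 log units; within the scatter) and a 1.9-fold lower number from compound 1 to compound 4 (0.28 log units; within the scatter), the 3,4-difluorophenyl, 3,4-dichlorophenyl and 4-nitrophenyl groups on the carbonyl carbon are not told apart in this assay. The aryl on the carbon with a double bond to nitrogen can now be read as well: 4-nitrophenyl in place of 2-(trifluoromethyl)phenyl gives a 1.7-fold lower number from compound 2 to compound 4 (0.23 log units; within the scatter). No measured evidence bears on these numbers.

Open, on these data alone, is whether an amine or a carboxylic acid in place of these aryl groups on the carbonyl carbon would give a step beyond the scatter.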